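The source may hold more compounds than are shown below. What is called first, only, known or untested is meant among the compounds shown, and "the series" means these compounds.

Measured so far in a functional assay on Ehrlich cells (Mus musculus) for cytotoxicity, read by trypan blue exclusion, with a stated time of 2 h, tested at 25 ug/mL; a higher number here means a stronger effect of the compound at the concentration tested, a lower number a weaker effect:
- compound 1 `Cc1ccc(C2C(C#N)=C(N)N(c3ccc(S(N)(=O)=O)cc3)C3=C2CCCC3)cc1` gives 30%
- compound 2 `COc1ccccc1C1C(C#N)=C(N)N(c2ccc(S(N)(=O)=O)cc2)C2=C1CCCC2` gives 40%
- compound 3 `N#CC1=C(N)N(c2ccc(S(N)(=O)=O)cc2)C2=C(CCCC2)C1c1ccc(Cl)cc1Cl` gives 50%

Compound 2 stands second highest of the three numbers. Its nearest neighbour is compound 1: the step of a number 10 percentage points higher from compound 1 to compound 2 (within the scatter) is too small to count as a real difference. Towards compound 3 the step of a number 10 percentage points higher from compound 2 to compound 3 (within the scatter) is likewise within the usual spread of repeated tests, while the longer step of a number 20 percentage points higher from compound 1 to compound 3 (beyond the scatter) just crosses it. All three compounds share one core and differ only in the group on a single saturated ring carbon.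

Compound 4 `N#CC1=C(N)N(c2ccc(S(N)(=O)=O)cc2)C2=C(CCCC2)C1c1c(O)ccc2ccccc12` is the next compound, and it keeps that pattern: 2-hydroxynaphthalen-1-yl in place of 2-methoxyphenyl on a saturated ring carbon

The two measured steps at this position that start or end at compound 2 both stayed inside the scatter, and even the widest swing seen at this position was only modest. Nothing measured yet carries a hydroxyl or a second fused aromatic ring there, so the expectation can only rest on how little this position has moved so far. The step of a number 2 percentage points higher from compound 2 to compound 4 (within the scatter) is therefore expected to be small. Compound 4 is estimated at 42% in this assay, with a likely range from 25% to 60%.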

Compound 4, a percentage reported as activity, at one concentration (the size of the read-out at that concentration, not a potency): 5%
Compound 4: the middle estimate sits 37 percentage points above what was measured, outside the stated range (below it).
By their numbers in this assay, from the lowest: compound 4; then compounds 1, 2 and 3 (each within the scatter of the next, the first and the last beyond it).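

The position looked forgiving until now, but it is not: in this assay the 2-hydroxynaphthalen-1-yl group brings a number 35 percentage points lower from compound 2 to compound 4 (beyond the scatter) and a number 45 percentage points lower from compound 3 to compound 4 (beyond the scatter) and also a number 25 percentage points lower from compound 1 to compound 4 (beyond the scatter), which leaves compound 4 as the weakest of the four. The first two of these steps are large, whereas the widest swing among the 4-methylphenyl, 2-methoxyphenyl and 2,4-dichlorophenyl groups was only modest, so the group on this saturated ring carbon can strongly change the effect on these cells. The change adds a second six-membered aromatic ring and a hydrogen-bond donor together, and nothing measured here says what lies behind the fall.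

The compounds shown cannot separate those two additions, and a plain naphthalen-1-yl group without the hydroxyl, set beside a 2-hydroxyphenyl group, would pull them apart. It also stays open whether a 2-aminonaphthalen-1-yl group would behave like compound 4, and how any of these compounds would compare at other concentrations, since each number here comes from a single concentration.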